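Benzyloxymethyl series: methoxy on the benzyl ring

A few compounds are considered here, and "the series" means these few. Any claim that something is new, unique, unknown or untested is made for them only; others in the source may bear on it.

Three compounds of the shared core have numbers in a functional assay on A549 cells (Homo sapiens) for cytotoxicity, read by MTT assay, with a stated time of 72 h; on this read-out lower numbers stand for stronger inhibition and higher numbers for weaker inhibition. Compound 1 `[O-][n+]1nc(NCOC2CCCCC2)[n+]([O-])c2ccccc21` gives 5180 nM. Compound 2 `O=[N+]([O-])c1cccc(COCNc2n[n+]([O-])c3ccccc3[n+]2[O-])c1` gives 2890 nM. Compound 3 `[O-][n+]1nc(NCOCc2ccccc2)[n+]([O-])c2ccccc21` gives 10800 nM, the highest of the three numbers: the step is a 2.1-fold higher number from compound 1 to compound 3 (0.32 log units; beyond the scatter) and a 3.7-fold higher number from compound 2 to compound 3 (0.57 log units; beyond the scatter).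

Compound 4 `COc1ccc(COCNc2n[n+]([O-])c3ccccc3[n+]2[O-])cc1` is the next member, not yet measured in this assay. Compared with compound 3 the change is methoxy in place of hydrogen on an aromatic carbon.

For the measured compounds named here, of the measured steps, the one from compound 2 to compound 3 bears most directly: it also concerns a substituent on the benzyl ring of the same core, and removing nitro there gave a 3.7-fold higher number from compound 2 to compound 3 (0.57 log units; beyond the scatter). The step from compound 1 to compound 3 exchanges the whole ring and is less informative. Going by the values given here, no measured pair shows methoxy itself, so how far a methoxy tracks the nitro result is open.

Compound 4 is therefore expected to come in somewhat below compound 3, by an estimated 1.5-fold lower number from compound 3 to compound 4 (0.19 log units; within the scatter), with no change beyond the scatter also possible. The estimate for compound 4 in this assay is 7000 nM, within a range of 3000 nM to 16000 nM.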

Compound 4, half-maximal inhibitory concentration: 7640 nM
Estimate against measurement, compound 4: 1.1-fold (0.04 log units) below; measured number inside the range.
By their numbers in this assay, from the lowest: compounds 2, 1, 4 and 3 (each within the scatter of the next, the first and the last beyond it).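

In this assay, the change from phenyl to 4-methoxyphenyl gives a 1.4-fold lower number from compound 3 to compound 4 (0.15 log units; within the scatter), so methoxy on this aromatic carbon, para to a large group, leaves compound 4 within the scatter of compound 3. This sets methoxy apart from the nitro on the benzyl ring of compound 2, whose removal reads a 3.7-fold higher number from compound 2 to compound 3 (0.57 log units; beyond the scatter): a substituent on this ring does not by itself give a step beyond the scatter, and the nitro result does not carry over to methoxy. Nothing at hand bears on why the two substituents differ in this way.

On these data alone, whether an amine, a carboxylic acid or a chlorine on the same aromatic carbon would give a step beyond the scatter remains open, as does whether a longer chain such as butoxy would read as methoxy does. Also open, as far as these compounds go, is how nitro and methoxy would compare on one and the same ring carbon, since the two steps available here cannot settle that point.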